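Carboxy to tetrazolyl on the saturated ring of compound 1

The source may hold more compounds than are shown below. What is called first, only, known or untested is meant among the compounds shown, and "the series" means these compounds.

Among the measured compounds shown here, compound 1 `Cc1cccc(Cc2nc3cc(O[C@H]4CC[C@@H](C(=O)O)CC4)ccc3n2C)c1` gives 30 nM in an assay on isolated protein for inhibition of Long-chain-fatty-acid--CoA ligase 1 (Mus musculus), read by mass spectrometry, with a stated time of 90 min, in the presence of a further agent that is not named here (a lower number here means a stronger inhibitor, a higher number a weaker inhibitor), the lowest of the three numbers measured so far. Compound 3 `Cc1cccc(Cc2nc3cc(O[C@H]4CC[C@@H](C(=O)O)CC4)c(Cl)cc3n2C)c1` stands nearest to it, with 100 nM; compound 2 `Cc1cccc(Oc2nc3cc(O[C@H]4CC[C@@H](C(=O)O)CC4)ccc3n2C)c1` stands furthest, with 21000 nM. The two measured steps are a 3.3-fold higher number from compound 1 to compound 3 (0.52 log units; beyond the scatter) and a 700-fold higher number from compound 1 to compound 2 (2.85 log units; beyond the scatter). Both concern the benzimidazole-type core and its pendant ring, not the saturated ring that carries the acid.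

Compound 4 `Cc1cccc(Cc2nc3cc(O[C@H]4CC[C@@H](c5nnn[nH]5)CC4)ccc3n2C)c1` differs from compound 1 in one place: 1H-tetrazol-5-yl in place of carboxy on a saturated ring carbon. Neither measured step touches this position, so no direct comparison exists within the series; the shared core and the pendant ring stay exactly as in compound 1. The exchange keeps one hydrogen-bond donor and gains acceptors, as counted. In the absence of a step on this position, the expectation rests only on compound 1 itself and on the observation that the series tolerates the smaller change of the chloro step (a 3.3-fold higher number from compound 1 to compound 3 (0.52 log units; beyond the scatter)) at modest cost.

Compound 4 is therefore expected to land close to compound 1, with a step of a 2.0-fold higher number from compound 1 to compound 4 (0.30 log units; within the scatter) that may run either way within the scatter or slightly beyond it. The estimate for compound 4 in this assay is 60 nM, with a range from 15 nM to 300 nM.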

Compound 4, half-maximal inhibitory concentration: 25 nM
Compound 4: middle estimate off by 2.4-fold (0.38 log units), on the high side, within the range that was stated.
By their numbers in this assay, from the lowest: compounds 4 and 1 (each within the scatter of the next); then compound 3; then compound 2.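

In this assay, among the compounds shown here, the only change so far on the saturated ring carbon gives a 1.2-fold lower number from compound 1 to compound 4 (0.08 log units; within the scatter), so carboxy and 1H-tetrazol-5-yl cannot be told apart at this position on the shared core. For this pair, a carboxy group is therefore not required to hold a number of this size: one five-membered aromatic ring with 4 hetero atoms, carrying 5 heavy atoms in place of 3, serves equally well. This position thus behaves differently from the two places changed earlier, where a 3.3-fold higher number from compound 1 to compound 3 (0.52 log units; beyond the scatter) and a 700-fold higher number from compound 1 to compound 2 (2.85 log units; beyond the scatter) both lie beyond the scatter, although no evidence at hand accounts for the match between the two groups.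

What the compounds shown leave open is whether a primary amide, a methyl ester or a sulfonamide on the same ring carbon would also match compound 1, or whether a longer chain carrying the carboxylic acid or the tetrazole would be accepted there. Also open is whether 1H-tetrazol-5-yl would read the same on the chloro core of compound 3 or the 3-methylphenoxy core of compound 2, since the exchange is shown on the core of compound 1 alone.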